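Swapping a Chlorophenyl for Pyridyl on a Second Core

A few compounds are considered here, and "the series" means these few. Any claim that something is new, unique, unknown or untested is made for them only; others in the source may bear on it.

Compound 1 `Clc1ccc(-c2cc(-c3ccoc3)cc(-c3ccc(Cl)s3)n2)cc1` and compound 2 `Clc1ccc(-c2cc(-c3ccoc3)cc(-c3cccnc3)n2)s1` share one core and differ in a single group. In a functional assay on HCT-15 cells (Homo sapiens) for cytotoxicity, read by ELISA, with a stated time of 4 days (a lower number here means a stronger inhibitor, a higher number a weaker inhibitor), compound 1 gives 640 nM, and compound 2 gives 720 nM. The change between them, (pyridin-3-yl in place of 4-chlorophenyl on an aromatic carbon), made a step of a 1.1-fold higher number from compound 1 to compound 2 (0.05 log units; within the scatter).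

Compound 3 `Cc1ccsc1-c1cc(-c2ccc(Cl)o2)cc(-c2ccc(Cl)cc2)n1` is built on a different core; how the two cores differ is not broken down here. In this assay compound 3 gives 30300 nM, the highest of the three numbers, beyond the scatter from both compound 1 and compound 2.

Compound 4 `Cc1ccsc1-c1cc(-c2ccc(Cl)o2)cc(-c2cccnc2)n1` has not been measured. Going by the values given here, it arises from compound 3 through (pyridin-3-yl in place of 4-chlorophenyl on an aromatic carbon), the same kind of change as the one from compound 1 to compound 2, though not the same: in compound 1 the place is meta to a 5-chlorothiophen-2-yl group and meta to a furan-3-yl group, whereas in compound 3 it is meta to a 3-methylthiophen-2-yl group and meta to a 5-chlorofuran-2-yl group.

In this assay the expected step is a 1.1-fold higher number from compound 3 to compound 4 (0.04 log units; within the scatter), close to the earlier one, and that rests on a single measured instance, because a 1.1-fold higher number from compound 1 to compound 2 (0.05 log units; within the scatter) stayed within the scatter. Nothing measured shows how this change behaves on the core of compound 3, so the range is wide. In this assay compound 4 is therefore estimated at 33000 nM, with a likely range from 11000 nM to 100000 nM.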

Compound 4, half-maximal inhibitory concentration: > 50000 nM
Compound 4: no number, only a limit; the forecaster's own chance of this, stated with the estimate: 15%; middle value at least 1.5-fold (0.18 log units) away from the limit.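

In this assay compound 4 gives > 50000 nM, which is a limit of the assay and not a number, so the true value is not known. Replacing 4-chlorophenyl with pyridin-3-yl on the core of compound 3 therefore gives only a floor for the size of the step, an at least 1.6-fold higher number from compound 3 to compound 4 (0.21 log units; that floor lies within the scatter), and the real step could be close to that floor or much larger. On neither core does this replacement lower the number, but that is not enough to show whether the change carries over from one core to the other with the same size, since one of the two steps has no upper end: the same change on two cores in this assay, a 1.1-fold higher number (0.05 log units; within the scatter) from compound 1 to compound 2 and an at least 1.6-fold higher number (0.21 log units; that floor lies within the scatter) from compound 3 to compound 4; the limit leaves it open whether they differ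

The compounds shown hold only two groups at this place, 4-chlorophenyl and pyridin-3-yl, so they leave open what a quite different group on the same aromatic carbon, such as an amine, a carboxylic acid or a longer chain, would do on either core. Also open, from the compounds shown here alone, is how far past the limit compound 4 really lies, and whether the same replacement on a third core would follow the step seen on the core of compound 1 or the one seen on the core of compound 3.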